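A Cytotoxicity Step from a Phenoxy to an Oxadiazole

This account rests on a few compounds, and the source may have more. Where it says the series, first, only, none or still open, it means among the compounds named here.

Two members of a shared core have been tested in an ADME assay on Raji cells (Homo sapiens) for cytotoxicity, read by CellTiter-Glo and resazurin assay, with a stated time of 72 h (on this read-out lower numbers stand for an effect already at smaller amounts and higher numbers for an effect only at larger amounts of compound), and both came back only as limits. Compound 1 `CCOC(=O)CCCCCOc1cccc(CN(C(=O)c2ccc(-c3cccc(C(C)=O)c3)cc2)C(C)C)c1` gave a limit of > 26000 nM in this assay. Compound 2 `CCOC(=O)CCCCCOc1cccc(CN(C(=O)c2ccc(-c3cccc(Oc4ccccc4)c3)cc2)C(C)C)c1` likewise gave a limit of > 19600 nM in this assay. Going by the values given here, the only step between the measured compounds, a step that the two limits leave unreadable from compound 1 to compound 2, cannot be sized, since both of its ends are limits, as the limit of > 19600 nM in this assay, at which 1 of the 2 values shown sits, and the limit of > 26000 nM in this assay, at which 1 of the 2 values shown sits, show. Among the compounds with values here, compound 2 therefore stands at a limit in this assay, and the one further value shown beside it is also a limit.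

Compound 3 `CCOC(=O)CCCCCOc1cccc(CN(C(=O)c2ccc(-c3cccc(-c4nnc(C)o4)c3)cc2)C(C)C)c1` differs from compound 2 by 5-methyl-1,3,4-oxadiazol-2-yl in place of phenoxy on an aromatic carbon. Within the data shown here, no measured step runs through that change, and the single step on record, which traded acetyl for phenoxy on an aromatic carbon, stayed unreadable between the two limits. Nothing in these data points to a change beyond the usual scatter, so compound 3 is expected to remain at or near the limit, with an expected step that the limit leaves unreadable from compound 2 to compound 3. The estimate for compound 3 in this assay is 25000 nM, expected to fall between 10000 nM and 60000 nM.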

Compound 3, half-maximal effective concentration: > 26000 nM
Compound 3: a limit, no number; the forecaster's own chance of this, stated with the estimate: 85%; middle value at least 1.0-fold (0.01 log units) away from the limit.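

In this assay compound 3 gave > 26000 nM as a limit and not as a number. Going by these compounds alone, with compound 1 and compound 2 also at limits, no step to compound 3 from either can be read. The compounds shown leave open at what concentration any of the three would reach a half-maximal effect, and whether acetyl, phenoxy and 5-methyl-1,3,4-oxadiazol-2-yl differ at all.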